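The compounds below may be only part of what the source reports. "The series", "measured", "known", "first", "only" and "open" are said of these compounds alone.

The series rests on compound 1 `N#CC1=C(N)N(c2ccc(S(N)(=O)=O)cc2)C2=C(C(=O)CCC2)C1c1ccc(Cl)cc1Cl`, which in a functional assay on Ehrlich cells (Mus musculus) for cytotoxicity, read by trypan blue exclusion, with a stated time of 2 h, tested at 25 ug/mL (a lower number here means a weaker effect, a higher number a stronger effect of the compound at the concentration tested), gives 50%. Compound 2 `CCCCNC(=S)NC1=C(C#N)C(c2ccc(Cl)cc2Cl)C2=C(CCCC2=O)N1c1ccc(S(N)(=O)=O)cc1` carries a butylthiourea on the amine and gives 30% in this assay, so that a number 20 percentage points lower from compound 1 to compound 2 (beyond the scatter). Compound 3 `C=CCNC(=S)NC1=C(C#N)C(c2ccc(Cl)cc2Cl)C2=C(CCCC2=O)N1c1ccc(S(N)(=O)=O)cc1` carries an allylthiourea in the same place and gives 30% in this assay, with a number 20 percentage points lower from compound 1 to compound 3 (beyond the scatter). Between the two thioureas the read-out is unchanged: no change at the digits printed from compound 2 to compound 3 (within the scatter). Compound 3 therefore stands level with compound 2 and sits beyond the scatter under compound 1.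

Compound 4 `N#CC1=C(NC(=S)Nc2ccccc2)N(c2ccc(S(N)(=O)=O)cc2)C2=C(C(=O)CCC2)C1c1ccc(Cl)cc1Cl` differs from compound 3 by phenyl in place of allyl on an amide-type nitrogen. Within the data shown here, the only measured step that bears on this position is the exchange of one thiourea substituent for another, where no change at the digits printed from compound 2 to compound 3 (within the scatter). On that ground the step from compound 3 to compound 4 is expected to be no change at the digits printed from compound 3 to compound 4 (within the scatter), with no movement beyond the scatter. Compound 4 is therefore estimated at 30% in this assay, within a range from 20% to 42%.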

Compound 4, a percentage reported as activity, at one concentration (the size of the read-out at that concentration, not a potency): 50%
Compound 4: middle estimate off by 20 percentage points, on the low side, and the stated range ends below it.
By their numbers in this assay, from the lowest: compounds 2 and 3 (each within the scatter of the next); then compounds 1 and 4 (each within the scatter of the next).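

In this assay the substituent on this amide-type nitrogen proves to matter after all: phenyl in place of allyl gives a number 20 percentage points higher from compound 3 to compound 4 (beyond the scatter) and phenyl in place of butyl gives a number 20 percentage points higher from compound 2 to compound 4 (beyond the scatter), although the exchange of butyl for allyl had moved nothing. Nor does the thiourea on the amine lower the read-out in every case, for with phenyl there is no change at the digits printed from compound 1 to compound 4 (within the scatter), so the lower numbers go with the butyl and allyl thioureas only. Nothing available here explains why phenyl parts from the two open chains.

The compounds shown leave open whether the higher number belongs to phenyl alone or extends to other groups on this nitrogen, such as benzyl, cyclohexyl or methoxyphenyl. They also leave open whether these steps would hold at other concentrations.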